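The source may hold more compounds than are shown below. What is called first, only, known or untested is meant among the compounds shown, and "the series" means these compounds.

Compound 1 `Cc1ccccc1-n1nncc1CN1C(=O)C2(C(C#N)=C(N)Oc3c2c2nc4ccccc4nc2c2ccccc32)c2ccccc21` — in a functional assay on HepG2 cells (Homo sapiens) for antiproliferative activity, read by MTT assay, with a stated time of 48 h (a lower number here means a stronger inhibitor, a higher number a weaker inhibitor), compound 1 gives > 50000 nM, a limit of the assay and not a number.
Compound 2 `Cc1cccc(-n2nncc2CN2C(=O)C3(C(C#N)=C(N)Oc4c3c3nc5ccccc5nc3c3ccccc43)c3ccccc32)c1` — in this assay compound 2 gives > 50000 nM, likewise a limit of the assay.
Compound 3 `N#CC1=C(N)Oc2c(c3nc4ccccc4nc3c3ccccc23)C12C(=O)N(Cc1cnnn1-c1ccc(Br)cc1)c1ccccc12` — in this assay compound 3 gives > 50000 nM, again a limit of the assay.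

Compound 1 therefore stands nowhere on a scale of numbers; it sits at the limit, and so do the other two values shown, as the limit of > 50000 nM in this assay, at which 3 of the 3 values shown sit, records. The step that the two limits leave unreadable from compound 1 to compound 2 cannot be read, and the same holds for a step that the two limits leave unreadable from compound 1 to compound 3 and a step that the two limits leave unreadable from compound 2 to compound 3. Exchanging the aryl group on the triazole nitrogen among three variants has given no measurable number in any case.

Compound 4 `N#CC1=C(N)Oc2c(c3nc4ccccc4nc3c3ccccc23)C12C(=O)N(Cc1cnnn1-c1ccc(N)cc1)c1ccccc12` carries the change (4-aminophenyl in place of 2-methylphenyl on an aromatic nitrogen). The three measured steps bear on it only in that they all concern the same aryl group on the same aromatic nitrogen, and none of them produced a readable size. No direction of change can be expected from them; the most that the data support is that compound 4 is expected to remain near the limit as well, with a step that the limit leaves unreadable from compound 1 to compound 4 expected to be small or unreadable. Compound 4 is accordingly estimated at 60000 nM, within 20000 nM to 200000 nM.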

Compound 4, half-maximal inhibitory concentration: > 50000 nM
Compound 4: a limit, no number; the forecaster's own chance of this, stated with the estimate: 75%; the middle value lies beyond the limit too.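

Within the data shown here, compound 4 joins compound 1, compound 2 and compound 3 at a limit of the assay and not a number, so no step from compound 4 to the other three can be read: the limit of > 50000 nM in this assay, at which 4 of the 4 values shown sit.

The compounds shown leave open whether any aryl group on the triazole nitrogen of the shared core gives a readable value in this assay at all.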